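Trimethoxyphenyl in Place of Fluorophenyl on the Amine Nitrogen

A few compounds are considered here, and "the series" means these few. Any claim that something is new, unique, unknown or untested is made for them only; others in the source may bear on it.

Compound 1 `O=C(/C=C\Nc1ccc(F)cc1)c1cn(-c2ccccc2)nc1-c1ccc(F)cc1`: > 50000 nM in an ADME assay on HaCaT cells (Homo sapiens) for antiproliferative activity, read by MTT assay, with a stated time of 48 h (on this read-out lower numbers stand for stronger inhibition and higher numbers for weaker inhibition), which is a limit of the assay rather than a number.
Compound 2 `COc1ccc(-c2nn(-c3ccccc3)cc2C(=O)/C=C\Nc2ccc(C(F)(F)F)cc2)cc1`: > 50000 nM in this assay, again a limit and not a number.
Compound 3 `COc1cc(-c2nn(-c3ccccc3)cc2C(=O)/C=C\Nc2ccc(F)cc2)cc(OC)c1OC`: 25700 nM in this assay.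

All three compounds share one core and differ in the aryl groups hung on it. Compound 3 is the only one of the three that returns an actual number in this assay; compounds 1 and 2 both sit at the limit of > 50000 nM in this assay, at which 2 of the 3 values shown sit, so nothing can be said about how far apart they are, or how far either is from compound 3.

Compound 4 `COc1cc(N/C=C\C(=O)c2cn(-c3ccccc3)nc2-c2cc(OC)c(OC)c(OC)c2)cc(OC)c1OC` is the next compound in line. Its difference from compound 3 is 3,4,5-trimethoxyphenyl in place of 4-fluorophenyl on an amine nitrogen. Among the compounds with values here, no two measured compounds differ from each other in just one place, so no measured step gives a yardstick for a change of this kind, and the data offer no basis for expecting a shift in either direction. The step from compound 3 to compound 4 in this assay is therefore expected to stay within the usual scatter, a 1.2-fold lower number from compound 3 to compound 4 (0.07 log units; within the scatter). On that basis compound 4 is estimated to give 22000 nM in this assay, with a range from 6000 nM to 60000 nM.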

Compound 4, half-maximal inhibitory concentration: 20900 nM
Beside the measured number, compound 4's estimate is 1.1-fold (0.02 log units) above it; the range from low to high includes it.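

Within the data shown here, this is the first comparison in which only one place changes, and in this assay it gives a 1.2-fold lower number from compound 3 to compound 4 (0.09 log units; within the scatter), so compound 3 and compound 4 cannot be told apart. On this amine nitrogen, then, 3,4,5-trimethoxyphenyl, with more heavy atoms than 4-fluorophenyl and with hydrogen-bond acceptors that 4-fluorophenyl lacks, gives a result no different from that of the group it replaces, at least with the rest of the molecule held as it is in these two compounds. Nothing shown here accounts for this result or says what it reflects in the cells.

This single pair cannot show whether other groups on the same nitrogen, such as a plain phenyl, a pyridine or a phenyl carrying a carboxylic acid or an amine, would also leave the number in place. Among these compounds, it also leaves open whether the same exchange would give so small a step on a core carrying a different aryl group, for no second pair tests that.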